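Swapping the piperidine substituent for a methylpiperazine

This account rests on a few compounds, and the source may have more. Where it says the series, first, only, none or still open, it means among the compounds named here.

Three compounds share a core, an amide linking a methanesulfonamide-bearing aryl to a trifluoromethyl-substituted pyridine. They differ only in the group on the pyridine carbon next to the ring nitrogen. Compound 1 `CC(C(=O)NCc1ccc(C(F)(F)F)nc1NCc1ccccc1)c1ccc(NS(C)(=O)=O)c(F)c1` carries benzylamino there and in a functional assay on CHO-K1 cells for antagonist activity at transient receptor potential cation channel subfamily V member 1 (Homo sapiens), read by FLIPR (a higher number here means a weaker inhibitor, a lower number a stronger inhibitor), compound 1 gives 15.8 nM. Compound 2 `CC(C(=O)NCc1ccc(C(F)(F)F)nc1N(C)c1ccccc1)c1ccc(NS(C)(=O)=O)c(F)c1` carries methyl(phenyl)amino, and compound 2 gives 0.9 nM. Compound 3 `CC(C)OC1CCN(c2nc(C(F)(F)F)ccc2CNC(=O)C(C)c2ccc(NS(C)(=O)=O)c(F)c2)CC1` carries 4-isopropoxypiperidin-1-yl, and compound 3 gives 3 nM, standing second highest of the three: a 5.3-fold lower number from compound 1 to compound 3 (0.72 log units; beyond the scatter), while a 3.3-fold higher number from compound 2 to compound 3 (0.52 log units; beyond the scatter).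

Compound 4 `CC(C(=O)NCc1ccc(C(F)(F)F)nc1N1CCN(C)CC1)c1ccc(NS(C)(=O)=O)c(F)c1` is the next variation: 4-methylpiperazin-1-yl in place of 4-isopropoxypiperidin-1-yl on an aromatic carbon. Among the compounds with values here, no measured step covers this exact exchange; the two steps that end at compound 3 show that changing this group moves this assay by modest amounts in either direction. Since the entering group is a smaller saturated ring without the isopropoxy, the expected step is a modest rise, a 2.7-fold higher number from compound 3 to compound 4 (0.43 log units; beyond the scatter), giving an estimated value for compound 4 of 8 nM, within a range from 2 nM to 30 nM.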

Compound 4, inhibition constant: 146 nM
Estimate against measurement, compound 4: 18-fold (1.26 log units) below, and the stated range ends below it.
By their numbers in this assay, from the lowest: compound 2; then compound 3; then compound 1; then compound 4.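

Two saturated rings on this carbon need not behave alike: replacing 4-isopropoxypiperidin-1-yl with 4-methylpiperazin-1-yl gives a 49-fold higher number from compound 3 to compound 4 (1.69 log units; beyond the scatter) and so a larger step than any among the first three compounds. In this assay the new group also trails methyl(phenyl)amino, with a 160-fold higher number from compound 2 to compound 4 (2.21 log units; beyond the scatter) as the largest step of the series, and benzylamino, with a 9.2-fold higher number from compound 1 to compound 4 (0.97 log units; beyond the scatter) as a smaller but still clear loss, which makes compound 4 the weakest of the four. Nothing available here offers an explanation for this drop in potency.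

The exchange removes the isopropoxy and adds a second ring nitrogen in one move, so the effect of each remains unresolved. A 4-methylpiperidin-1-yl group, with a ring carbon in place of that nitrogen, would help separate the two.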